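Pyrimidine amine series: ethyl to methoxy exchange on two cores

A few compounds are considered here, and "the series" means these few. Any claim that something is new, unique, unknown or untested is made for them only; others in the source may bear on it.

Measured so far:
compound 1, `CCc1nc(-c2ccc(OC(F)(F)F)cc2OC)c(CC)nc1NC(CC)CC`, 7.2 nM
compound 2, `CCc1nc(-c2ccc(OC(F)(F)F)cc2OC)c(OC)nc1NC(CC)CC`, 6.1 nM
compound 3, `CCc1nc(-c2ccc(OC)cc2C(F)(F)F)c(CC)nc1NC(CC)CC`, 4.4 nM

All three were read in an assay on IMR-32 cells for displacement of a labelled ligand from corticotropin-releasing factor receptor 1 (Homo sapiens), read by scintillation counting, with a stated time of 2 h; on this read-out higher numbers stand for weaker inhibition and lower numbers for stronger inhibition. Compound 1 gives 7.2 nM, compound 2 gives 6.1 nM and compound 3 gives 4.4 nM; the three numbers sit close together, and none of the gaps between them is beyond the scatter.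

One change is seen on compound 1: methoxy in place of ethyl on an aromatic carbon. Its step, a 1.2-fold lower number from compound 1 to compound 2 (0.07 log units; within the scatter), is within the scatter, so the change left the read-out essentially untouched.

Compound 4, `CCc1nc(NC(CC)CC)c(OC)nc1-c1ccc(OC)cc1C(F)(F)F`, not yet measured, carries the same kind of change on the core of compound 3: methoxy in place of ethyl on an aromatic carbon. The surroundings are not identical to those in the step from compound 1 to compound 2: there the position was ortho to a large group and meta to a (pentan-3-yl)amino group, whereas here it is ortho to a (pentan-3-yl)amino group and meta to a large group. The difference between the two cores themselves is not broken down here.

Going by the values given here, for compound 4 in this assay the expected step from its parent is a 1.2-fold lower number from compound 3 to compound 4 (0.06 log units; within the scatter), small, because a 1.2-fold lower number from compound 1 to compound 2 (0.07 log units; within the scatter) was within the scatter for the one example of this kind of change. Compound 4 is therefore estimated at 3.8 nM, with a likely range from 1.5 nM to 10 nM.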

Compound 4, inhibition constant: 2.2 nM
For compound 4 the middle estimate is 1.7-fold (0.24 log units) above the measured one; the range from low to high includes it.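

In this assay, methoxy in place of ethyl on an aromatic carbon gives a 2.0-fold lower number from compound 3 to compound 4 (0.30 log units; within the scatter), so this second example of the exchange also stays inside the usual scatter. Set beside the first example, it does not separate from it: the same change on two cores in this assay, a 1.2-fold lower number (0.07 log units; within the scatter) from compound 1 to compound 2 and a 2.0-fold lower number (0.30 log units; within the scatter) from compound 3 to compound 4, 1.7-fold (0.23 log units) apart, within the scatter of two such steps. Across these two cores, then, the exchange carries over with no shift in the read-out that can be told from scatter, but this does not show a real gain from methoxy on either core, and with only two pairs, whose surroundings at the changed carbon differ, it supports no rule for other cores or other positions in the series.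

The compounds shown leave open how the two cores compare in themselves, since the aryl groups of compound 1 and compound 3 differ in more than one place and no pair here isolates either group. Also open, going by these compounds, is whether the read-out would hold with a longer chain such as propyl, or with an amine or a nitrile, on the same aromatic carbon, and whether the exchange would behave alike with a smaller amine, such as cyclopropylamine, in place of the (pentan-3-yl)amino group.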